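Aryl swap on the ring nitrogen and adenosine receptor binding

This account rests on a few compounds, and the source may have more. Where it says the series, first, only, none or still open, it means among the compounds named here.

In an assay on CHO cells for displacement of a labelled ligand from adenosine receptor A3 (Homo sapiens), read by scintillation counting, with a stated time of 120 min, tested at 10 uM (a lower number here means less inhibition, a higher number more inhibition at the concentration tested (going by the name of the read-out)), compound 2 `Nc1scc(CN2CCN(c3c(F)cc(F)cc3F)CC2)c1C(=O)c1ccc(Cl)cc1` gives 0%, and compound 1 `Nc1scc(CN2CCN(c3cc(Cl)cc(Cl)c3)CC2)c1C(=O)c1ccc(Cl)cc1` gives 1%; the two numbers stand within the scatter of each other. Compound 3 `Nc1scc(CN2CCN(c3cccc(Cl)c3)CC2)c1C(=O)c1ccc(Cl)cc1` differs from compound 2 by 3-chlorophenyl in place of 2,4,6-trifluorophenyl on an amine nitrogen in a ring. Going by the values given here, the one measured step that bears on this change is the aryl exchange at the same ring nitrogen, a number 1 percentage points lower from compound 1 to compound 2 (within the scatter), which left the inhibition essentially unmoved. Compound 3 is therefore expected to show a step of a number 1 percentage points higher from compound 2 to compound 3 (within the scatter), none beyond the scatter, with an estimate of 1% and a range from -5% to 8%.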

Compound 3, a percentage reported as inhibition, at one concentration (the size of the read-out at that concentration, not a potency): 1%
Beside the measured number, compound 3's estimate shows no gap at the digits printed; low and high end bracket the measured number.
By their numbers in this assay, from the lowest: compounds 2, 1 and 3 (each within the scatter of the next).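

In this assay the step to 3-chlorophenyl reads a number 1 percentage points higher from compound 2 to compound 3 (within the scatter) and the single-chlorine comparison reads no change at the digits printed from compound 1 to compound 3 (within the scatter) for hydrogen in place of chloro on an aromatic carbon. The second chlorine of compound 1 therefore makes no readable difference, and all three aryl groups on the amine nitrogen in a ring stand within the scatter of one another. Nothing measured gives a reason for this.

Going by these compounds, what stays open is whether any group at this nitrogen lifts the inhibition at all. A pyridyl ring or a 4-methoxyphenyl group there remains untested in the compounds shown.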